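From compound 3 to compound 4: an aryl swap

A few compounds are considered here, and "the series" means these few. Any claim that something is new, unique, unknown or untested is made for them only; others in the source may bear on it.

Measured so far in a functional assay on HL-60 cells (Homo sapiens) for inhibition, read by MTT assay, with a stated time of 72 h (a lower number here means a stronger inhibitor, a higher number a weaker inhibitor), as the only test:
- compound 1 `O=C(c1oc(C(F)(F)F)nc1-c1ccccc1F)N1CCN(c2cccc(Cl)c2)CC1` gives "not active" (no number reported)
- compound 2 `Cc1nc(-c2ccc(F)cc2)c(C(=O)N2CCN(c3cccc(Cl)c3)CC2)o1` gives 40.1 nM
- compound 3 `O=C(c1oc(C(F)(F)F)nc1-c1cccc(Cl)c1)N1CCN(c2cccc(Cl)c2)CC1` gives "not active" (no number reported)

Compound 3 has no single number and stands with compound 1 as the other entry without one. Only compound 2 gives a number here.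

Compound 4 `O=C(c1oc(C(F)(F)F)nc1-c1ccc(F)cc1)N1CCN(c2cccc(Cl)c2)CC1` is still to be measured in this assay and differs from compound 3 in one place. The change is 4-fluorophenyl in place of 3-chlorophenyl on an aromatic carbon, two ring bonds from the ring atom that bears a trifluoromethyl group.

Among the compounds with values here, no step between measured compounds is available, so the expected size of the move has no direct support. The entering 4-fluorophenyl also stands on compound 2, which gives 40.1 nM, and this favours an expected move towards stronger inhibition, from no number to a measurable one. The trifluoromethyl group stays, and compound 1 also carries it and gives "not active" (no number reported), so compound 4 may well return no number either. The estimated value for compound 4 is 200 nM, with an expected range of 20 nM to 3000 nM.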

Compound 4, half-maximal inhibitory concentration: "not active" (no number reported)
Compound 4 has no reported number here; no gap can be computed for the estimate.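

In this assay compound 3 gives "not active" (no number reported) and compound 4 gives "not active" (no number reported) so no step can be read between these two compounds. No measured evidence bears on this result. The compounds shown leave open whether any compound carrying the trifluoromethyl group returns a number in this assay at all.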